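The compounds below may be only part of what the source reports. "The series", "measured", "known", "first", "only" and "open" are said of these compounds alone.

Measured so far:
compound 1, `COc1ccc(F)cc1Nc1cc(NC(=O)Nc2c(Cl)cccc2Cl)ncn1`, 38.1%
compound 2, `CCc1cccc(Nc2cc(NC(=O)Nc3cc(OC)cc(OC)c3)ncn2)c1`, 23%
compound 3, `COc1cc(NC(=O)Nc2cc(Nc3cc(C)cc(F)c3)ncn2)cc(OC)c1`, 24.5%

In a functional assay on NCI-H520 cells (Homo sapiens) for inhibition, read by MTT assay, with a stated time of 48 h, tested at 10 uM (on this read-out lower numbers stand for less inhibition and higher numbers for more inhibition at the one concentration tested (going by the name of the read-out)), compound 3 gives 24.5% and stands second of the three numbers. Its nearest neighbour is compound 2, reached by the step of a number 1.5 percentage points higher from compound 2 to compound 3 (within the scatter), which lies within the scatter. Within the data shown here, compound 1 gives 38.1%, a higher number beyond the scatter; compound 1 differs from compound 3 at the urea end as well, so no single step connects them.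

Compound 4, `COc1cc(NC(=O)Nc2cc(Nc3cc(F)ccc3OC)ncn2)cc(OC)c1`, differs from compound 3 by 5-fluoro-2-methoxyphenyl in place of 3-fluoro-5-methylphenyl on a nitrogen on an aromatic ring. Among the measured compounds shown here, the only measured step at this nitrogen is a number 1.5 percentage points higher from compound 2 to compound 3 (within the scatter), and it stayed within the scatter. Compound 1 carries the entering 5-fluoro-2-methoxyphenyl on the same nitrogen, but with a different urea partner, so its value bears only loosely on compound 4. For the step from compound 3 to compound 4 no change beyond the scatter is expected, with at most a slight lean upward: a number 3.5 percentage points higher from compound 3 to compound 4 (within the scatter). Compound 4 is estimated at 28%, in the range 15% to 42%.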

Compound 4, a percentage reported as inhibition, at one concentration (the size of the read-out at that concentration, not a potency): 38%
Compound 4: middle estimate off by 10 percentage points, on the low side, within the range that was stated.
By their numbers in this assay, from the lowest: compounds 2 and 3 (each within the scatter of the next); then compounds 4 and 1 (each within the scatter of the next).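

In this assay the nitrogen on an aromatic ring now gives steps beyond the scatter: with 5-fluoro-2-methoxyphenyl entering, the read is a number 13.5 percentage points higher from compound 3 to compound 4 (beyond the scatter) and a number 15 percentage points higher from compound 2 to compound 4 (beyond the scatter), whereas the earlier step at this place, a number 1.5 percentage points higher from compound 2 to compound 3 (within the scatter), stayed within it. With 5-fluoro-2-methoxyphenyl held on that nitrogen, 3,5-dimethoxyphenyl in place of 2,6-dichlorophenyl on an amide-type nitrogen reads a number 0.1 percentage points lower from compound 1 to compound 4 (within the scatter), so the two urea partners stand level in this one pair. No measurement at hand accounts for these steps.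

As far as these compounds go, it remains open which part of 5-fluoro-2-methoxyphenyl carries the step, and whether 2,6-dichlorophenyl would read the same alongside 3-fluoro-5-methylphenyl or 3-ethylphenyl. Also open, from the compounds shown here alone, is how a morpholine or a carboxylic acid on that ring would read.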